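Trifluoromethyl to Fluoro: Expecting the Cytotoxicity of Compound 4

The compounds below may be only part of what the source reports. "The series", "measured", "known", "first", "only" and "open" are said of these compounds alone.

Three compounds have been measured in a functional assay on L6 cells (Rattus norvegicus) for cytotoxicity; on this read-out higher numbers stand for weaker inhibition and lower numbers for stronger inhibition:

Compound 1, `CONC(=N)c1ccc(-c2ccc(-c3ccc(C(=N)NOC)cc3)c(F)c2)cc1`, gives 8500 nM.
Compound 2, `CONC(=N)c1ccc(-c2ccc(-c3ccc(C(=N)NOC)cc3)c(C(F)(F)F)c2)cc1`, gives 42200 nM.
Compound 3, `N=C(NO)c1ccc(-c2ccc(-c3ccc(/C(N)=N\O)cc3)cc2C(F)(F)F)cc1`, gives 13300000 nM.

Compound 3 gives by far the highest number of the three. Compound 2 and compound 1 differ in a single place, (fluoro in place of trifluoromethyl on an aromatic carbon), and that step was a 5.0-fold lower number from compound 2 to compound 1 (0.70 log units; beyond the scatter).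

Compound 4, `N=C(NO)c1ccc(-c2ccc(-c3ccc(/C(N)=N\O)cc3)cc2F)cc1`, has not yet been measured. It differs from compound 3 by fluoro in place of trifluoromethyl on an aromatic carbon, the same change at the same kind of place. How the core of compound 3 differs from the core of compound 2 is not broken down here.

Because the step of a 5.0-fold lower number from compound 2 to compound 1 (0.70 log units; beyond the scatter) came from this very change, the step from compound 3 to compound 4 is expected to be about a 4.4-fold lower number from compound 3 to compound 4 (0.65 log units; beyond the scatter), with a wide range given the different core. Compound 4 is therefore estimated to give 3000000 nM, likely between 600000 nM and 15000000 nM.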

Compound 4, half-maximal inhibitory concentration: 29100 nM
Compound 4: middle estimate off by 100-fold (2.01 log units), on the high side, outside the stated range (below it).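

Replacing trifluoromethyl with fluoro on the core of compound 3 gave a 460-fold lower number from compound 3 to compound 4 (2.66 log units; beyond the scatter) in this assay. Going by these compounds alone, the direction of this change carried over from one core to the other, but its size did not: the same change on two cores in this assay, a 5.0-fold lower number (0.70 log units; beyond the scatter) from compound 2 to compound 1 and a 460-fold lower number (2.66 log units; beyond the scatter) from compound 3 to compound 4, 92-fold (1.96 log units) apart, beyond the scatter of two such steps With only two such pairs, this does not show why the cores respond so differently, nor how the change would behave on a further core.

The compounds shown carry only trifluoromethyl or fluoro at this place on the ring. From the compounds shown here alone, how a plain hydrogen, a chlorine or a methyl group there would read out on either core remains open.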